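The source may report more compounds than this note shows. Statements on the series, on what has been measured and on what is new or still open speak of the compounds shown alone.

Compound 3 `CO[C@H]1C(=O)N2C(C(=O)C(C)(C)C)=C(C)C(Sc3nc(=O)c(=O)[nH]n3C)S(=O)(=O)[C@H]12` gives 16.3 h in a physicochemical assay for pharmacokinetics, at 37 degrees C (a higher number here means that the compound lasts longer, a lower number that the compound disappears faster), the lowest of the three half-lives recorded here. Compound 2 `CO[C@H]1C(=O)N2C(C(=O)C(C)(C)C)=C(CSc3nnnn3C)C(Sc3nnnn3C)S(=O)(=O)[C@H]12` gives 24 h in this assay, a number within the scatter of compound 3. Compound 1 `CO[C@H]1C(=O)N2C(C(=O)c3ccccc3)=C(C)C(Sc3nnnn3C)S(=O)(=O)[C@H]12` gives 120 h in this assay, a gap from compound 3 that lies beyond the scatter. Compound 4 `CO[C@H]1C(=O)N2C(C(=O)C(C)(C)C)=C(C)C(Sc3nnnn3C)S(=O)(=O)[C@H]12` has not yet been measured. It differs from compound 3 in one place: a group of 6 heavy atoms (2 carbon, 4 nitrogen; one five-membered aromatic ring with 4 hetero atoms) in place of a group of 9 heavy atoms (4 carbon, 3 nitrogen, 2 oxygen; one six-membered aromatic ring with 3 hetero atoms), on a sulfur. Compound 4 shares the 1-methyl-1H-tetrazol-5-yl on sulfur with compound 1 and compound 2, whose values both exceed compound 3. The step from compound 3 to compound 4 is therefore expected to be upward and of moderate size, a 2.5-fold higher number from compound 3 to compound 4 (0.39 log units; beyond the scatter). Compound 4 is estimated at 40 h, within a range of 15 h to 110 h.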

Compound 4, half-life: 14.8 h
Beside the measured number, compound 4's estimate is 2.7-fold (0.43 log units) above it, and the stated range ends above it.
By their numbers in this assay, from the lowest: compounds 4, 3 and 2 (each within the scatter of the next); then compound 1.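

In this assay, 1-methyl-1H-tetrazol-5-yl on the sulfur in place of the six-membered ring group gives a step that stays within the scatter (a 1.1-fold lower number from compound 3 to compound 4 (0.04 log units; within the scatter)), and hydrogen in place of (1-methyl-1H-tetrazol-5-yl)sulfanyl also stays within it (a 1.6-fold lower number from compound 2 to compound 4 (0.21 log units; within the scatter)). Of the three changes, only tert-butyl in place of phenyl on a carbonyl carbon goes beyond the scatter (an 8.1-fold lower number from compound 1 to compound 4 (0.91 log units; beyond the scatter)). As far as these compounds go, whether a carboxylic acid or an amine in place of 1-methyl-1H-tetrazol-5-yl on the sulfur would alter the half-life remains open. No measurement shown explains any of these steps.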